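The source may report more compounds than this note shows. Statements on the series, on what has been measured and on what is new or still open speak of the compounds shown alone.

Working notes on the series. Of the compounds shown here, three built on one shared core have been measured in an assay on CHO cells for displacement of a labelled ligand from adenosine receptor A1 (Homo sapiens), read by scintillation counting, with a stated time of 3 h; a lower number here means a stronger inhibitor, a higher number a weaker inhibitor. Compound 1 `Nc1nc(-c2ccccc2)nc2sc(-c3ccccc3)nc12` gives 148 nM. Compound 2 `Nc1nc(-c2ccccc2)nc2sc(-c3ccco3)nc12` gives 33 nM. Compound 3 `Nc1nc(-c2cccc(CO)c2)nc2sc(-c3ccco3)nc12` gives 28 nM. The step of a 4.5-fold lower number from compound 1 to compound 2 (0.65 log units; beyond the scatter) is the only one so far that goes beyond the scatter. The step of a 1.2-fold lower number from compound 2 to compound 3 (0.07 log units; within the scatter) stays within it.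

Compound 2 thus holds the second highest of the three numbers; compound 3 sits nearest to it, within the scatter, and compound 1 sits furthest from it, beyond the scatter.

Compound 4 `COc1ccc(-c2nc(N)c3nc(-c4ccco4)sc3n2)cc1` differs from compound 2 by methoxy in place of hydrogen on an aromatic carbon. For the measured compounds named here, of the two measured steps, only the step from compound 2 to compound 3 bears on this change, because a 1.2-fold lower number from compound 2 to compound 3 (0.07 log units; within the scatter) also placed a small group on the same six-membered aromatic ring of carbon only and moved the number only within the scatter. The furan step from compound 1 to compound 2 concerns the other ring and says nothing about this position. No step beyond the scatter is therefore expected in this assay for compound 4.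

Compound 4 is expected to give about 30 nM, with a range from 12 nM to 75 nM. The expected step of a 1.1-fold lower number from compound 2 to compound 4 (0.04 log units; within the scatter) is estimated to remain within the scatter.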

Compound 4, inhibition constant: 47.7 nM
Beside the measured number, compound 4's estimate is 1.6-fold (0.20 log units) below it, within the range that was stated.
By their numbers in this assay, from the lowest: compounds 3, 2 and 4 (each within the scatter of the next); then compound 1.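

In this assay, a 1.4-fold higher number from compound 2 to compound 4 (0.16 log units; within the scatter) shows that methoxy can stand on an aromatic carbon of the six-membered aromatic ring of carbon only, para to a large group, without a step beyond the scatter. Until now, that ring had been read through hydroxymethyl alone in a 1.2-fold lower number from compound 2 to compound 3 (0.07 log units; within the scatter); methoxy is a second group there that stays within the scatter, and, unlike a 4.5-fold lower number from compound 1 to compound 2 (0.65 log units; beyond the scatter), neither step on this ring goes beyond it. No measurement at hand gives a reason for the small size of this step.

The compounds shown leave open whether an amine or a carboxylic acid at this same place, or a chain longer than methoxy, would also stay within the scatter of compound 2. They also leave open how methoxy would read on the other carbons of this ring, or on the core of compound 1, which carries phenyl where compound 2 carries furan-2-yl.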